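A few compounds are considered here, and "the series" means these few. Any claim that something is new, unique, unknown or untested is made for them only; others in the source may bear on it.

Among the measured compounds shown here, compound 3, `COc1ccc(Cl)cc1-c1cc(N)nc(Nc2ccc(C)cc2)c1`, sits at the low end of the numbers so far in an assay on Sf9 cells for inhibition of 1-acyl-sn-glycerol-3-phosphate acyltransferase beta (Homo sapiens) (a lower number here means a stronger inhibitor, a higher number a weaker inhibitor), where compound 3 gives 240 nM. Its nearest neighbour with a single number is compound 2, `COc1ccc(Cl)cc1-c1cc(N)cc(Nc2ccc(C)cc2)n1`, and in this assay compound 2 gives 29000 nM, a gap that lies well beyond the scatter. Compound 1, `COc1ccc(Cl)cc1-c1nc(N)nc(Nc2ccc(Cl)cc2)n1`, has been run more than once, and in this assay compound 1 gives 70 nM; 45 nM (2 entries); the repeat entries are recorded as the several entries of compound 1 in this assay, 70 nM; 45 nM (2 entries). No pair among these three differs in only one place, so no single step can be read from them.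

Compound 4, `CCOc1ccc(Cl)cc1-c1cc(N)nc(Nc2ccc(C)cc2)c1`, is the next compound to be measured. It differs from compound 3 by methyl in place of hydrogen on a saturated chain carbon bound to an oxygen on an aromatic ring. For the measured compounds named here, no comparable step has been measured. In this assay the estimated step is a 1.3-fold higher number from compound 3 to compound 4 (0.10 log units; within the scatter), none beyond the scatter. Compound 4 is therefore expected to give 300 nM, within a range of 100 nM to 900 nM.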

Compound 4, half-maximal inhibitory concentration: 490 nM
Estimate against measurement, compound 4: 1.6-fold (0.21 log units) below, within the range that was stated.
By their numbers in this assay, from the lowest: compound 3; then compound 4; then compound 2.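

Among the compounds shown here, the change from methoxy to ethoxy brings a 2.0-fold higher number from compound 3 to compound 4 (0.31 log units; beyond the scatter) in this assay, and this is the first single change that can be read. This position therefore takes the added methyl with only a modest loss, a step that lies just past the scatter rather than far beyond it. How far repeat entries of one compound can lie apart is seen in compound 1: the several entries of compound 1 in this assay, 70 nM; 45 nM (2 entries)

Going by these compounds, a single step gives no trend, and whether a longer chain such as propoxy or a branched one such as isopropoxy would raise the number further remains open. Also open, on these data alone, are what a hydroxyl in place of the methoxy would do and whether the same change would give a similar step on the core of compound 1.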